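Bromo for fluoro across two related cores

The source may hold more compounds than are shown below. What is called first, only, known or untested is meant among the compounds shown, and "the series" means these compounds.

Compound 1 `O=S(=O)(/C=C/c1ccc(F)cc1)Cc1ccc(Nc2ncnc3ccccc23)cc1` and compound 2 `O=S(=O)(/C=C/c1ccc(Br)cc1)Cc1ccc(Nc2ncnc3ccccc23)cc1` share one core; compound 3 `COc1cc2ncnc(Nc3ccc(CS(=O)(=O)/C=C/c4ccc(F)cc4)cc3)c2cc1OC` and compound 4 `COc1cc2ncnc(Nc3ccc(CS(=O)(=O)/C=C/c4ccc(Br)cc4)cc3)c2cc1OC` share another, and the difference between the two cores is not broken down here. In a functional assay on SW-620 cells (Homo sapiens) (on this read-out lower numbers stand for stronger inhibition of growth and higher numbers for weaker inhibition of growth), compound 1 gives 100000 nM. Compound 2 reaches only a limit of the assay, > 100000 nM. Compound 3 likewise reaches only a limit of the assay, > 100000 nM. The change from compound 1 to compound 2, (bromo in place of fluoro on an aromatic carbon), is the same change as that from compound 3 to compound 4, (bromo in place of fluoro on an aromatic carbon). From the compounds shown here alone, its measured step was a number no lower from compound 1 to compound 2 (the limit leaves the size open), and its size stays open because of the limit of > 100000 nM in this assay, at which 2 of the 3 values shown sit. Beside that measured step, the expected step is a number no higher from compound 3 to compound 4 (the limit leaves the size open). Compound 4 is therefore estimated at 100000 nM, most likely again as a limit, within 50000 nM to 200000 nM.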

Compound 4, concentration for 50% growth inhibition: 5000 nM
The estimate for compound 4 lay 20-fold (1.30 log units) above the measured number, and the stated range ends above it.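

On the core of compound 3, bromo in place of fluoro gives an at least 20-fold lower number from compound 3 to compound 4 (1.30 log units; beyond the scatter), a large move towards stronger inhibition of growth. In this assay, the change does not carry over as one fixed step from one core to the other: the same change on two cores in this assay, a number no lower (the limit leaves the size open) from compound 1 to compound 2 and an at least 20-fold lower number (1.30 log units; beyond the scatter) from compound 3 to compound 4, at least 20-fold (1.30 log units) apart, beyond the scatter of two such steps. From the compounds shown here alone, the step from compound 1 to compound 2 cannot be read, and the exact size of both steps and of the gap between them stays open because of the assay limit: the limit of > 100000 nM in this assay, at which 2 of the 4 values shown sit.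

The compounds shown leave open whether chloro, iodo or a methoxy group in the same place would behave like bromo on the core of compound 3. They also leave open whether an amine there would keep the step.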